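The source may report more compounds than this note shows. Statements on the series, on what has been measured and on what is new or still open speak of the compounds shown alone.

Of the compounds shown here, two of a shared core have been measured in an assay on isolated protein for inhibition of Aromatase (Homo sapiens), tested at 1 uM; on this read-out higher numbers stand for more inhibition at the one concentration tested (going by the name of the read-out) and lower numbers for less inhibition. Compound 1 `CC(C)CC1n2cncc2CN(CC2CC2)S1(=O)=O` gives 19% in this assay. Compound 2 `CC(C)OCC1n2cncc2CN([C@@H](C)c2ccc(Cl)cc2)S1(=O)=O` gives 23% in this assay. On these two numbers compound 2 stands alongside compound 1: the gap between them lies within the usual scatter of repeated measurements, so the two results read as the same modest level of inhibition, and no ranking between them is supported.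

The next compound, compound 3 `CC(C)CC1n2cncc2CN([C@@H](C)c2ccc(Cl)cc2)S1(=O)=O`, has not yet been measured. It differs from compound 2 at one place: isopropyl in place of isopropoxy on a saturated chain carbon bound to a saturated ring carbon. Compound 3 thus carries the same side chain as compound 1 while keeping the nitrogen substituent of compound 2. Neither measured pair offers a counted step for this change, so the expectation rests on the low level both compounds share. The step in this assay is expected to be a number 2 percentage points lower from compound 2 to compound 3 (within the scatter), not beyond the scatter in either direction. Compound 3 is therefore estimated to give about 21% in this assay, expected between 6% and 38%.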

Compound 3, a percentage reported as inhibition, at one concentration (the size of the read-out at that concentration, not a potency): 56%
Beside the measured number, compound 3's estimate is 35 percentage points below it, outside the stated range (above it).
By their numbers in this assay, from the lowest: compounds 1 and 2 (each within the scatter of the next); then compound 3.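

With the nitrogen substituent held fixed, isopropyl in place of isopropoxy on a saturated chain carbon bound to a saturated ring carbon gives in this assay a number 33 percentage points higher from compound 2 to compound 3 (beyond the scatter) and so shows that this position can strongly change the read-out, which the two earlier compounds, differing in more than one place, could not show. The isobutyl side chain does not bring this level on its own, since compound 1, which shares that chain but has a different nitrogen substituent, gives 19% while compound 3 gives 56% in this assay, so the higher number is seen only where isobutyl is paired with the nitrogen substituent of compound 3. The data at hand offer no measurement that accounts for the size of this step.

What the compounds shown leave open is whether the same change would raise inhibition with the nitrogen substituent of compound 1, or whether it is tied to the one carried by compound 2. They also leave open how far the read-out would move at this position with a longer chain such as n-hexyl, with a cyclohexyl ring, or with an amine at the end of the chain.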